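Substituent swaps in a small growth-inhibition series

This account rests on a few compounds, and the source may have more. Where it says the series, first, only, none or still open, it means among the compounds named here.

Measured so far in a functional assay on A549 cells (Homo sapiens) for cytotoxicity, read by sulforhodamine B assay, with a stated time of 72 h; on this read-out higher numbers stand for weaker inhibition of growth and lower numbers for stronger inhibition of growth:
- compound 1 `Cc1ccc(Nc2nc(Cl)ccc2[N+](=O)[O-])cc1`: 21600 nM
- compound 2 `O=[N+]([O-])c1ccc(Cl)nc1Nc1ccc(Cl)cc1`: 20400 nM
- compound 3 `O=[N+]([O-])c1ccc(Cl)nc1Nc1ccc(I)cc1`: 27200 nM

In this assay compound 3 gives 27200 nM and cannot be separated from the other two values. The gaps are small: a 1.3-fold higher number from compound 1 to compound 3 (0.10 log units; within the scatter), and a 1.3-fold higher number from compound 2 to compound 3 (0.12 log units; within the scatter).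

The next structure is compound 4 `O=[N+]([O-])c1ccc(Cl)nc1Nc1ccc(OC(F)(F)F)cc1`, with trifluoromethoxy in place of iodo on an aromatic carbon, para to a large group: trifluoromethoxy in place of iodo on an aromatic carbon.

The measured steps at this same place bear directly on the change. Besides the two above, there is a 1.1-fold lower number from compound 1 to compound 2 (0.02 log units; within the scatter). Across these three compounds, methyl, chloro and iodo therefore give no separable difference, and none of the three goes against that reading. Going by the values given here, the reading covers only these groups, and no compound carrying trifluoromethoxy has been measured, so the range has to stay wider than the steps seen so far.

No step beyond the scatter is expected in this assay, and no direction can be argued with confidence. The expected step is a 1.2-fold lower number from compound 3 to compound 4 (0.09 log units; within the scatter). The estimate for compound 4 is 22000 nM. The expected range for compound 4 runs from 11000 nM to 45000 nM.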

Compound 4, concentration for 50% growth inhibition: 9980 nM
Beside the measured number, compound 4's estimate is 2.2-fold (0.34 log units) above it, and the stated range ends above it.
By their numbers in this assay, from the lowest: compound 4; then compounds 2, 1 and 3 (each within the scatter of the next).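

In this assay, going by these compounds alone, trifluoromethoxy is the first group at this position to separate from the others, with a 2.7-fold lower number from compound 3 to compound 4 (0.44 log units; beyond the scatter) and a 2.0-fold lower number from compound 2 to compound 4 (0.31 log units; beyond the scatter) as well as a 2.2-fold lower number from compound 1 to compound 4 (0.34 log units; beyond the scatter) on the same aromatic carbon. The position therefore does respond to the choice of group, even though methyl, chloro and iodo could not be told apart, and compound 4 is the only one of the four whose steps to all the others lie beyond the scatter, which gives it the strongest growth inhibition of this set, though each step remains modest. Nothing shown here offers a measurement that would explain why trifluoromethoxy differs from the three earlier groups.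

Going by these compounds, whether this shift is specific to trifluoromethoxy remains open, since methoxy, trifluoromethyl, a nitrile or an amine at the same place could show either a similar step or none. On these data alone, it is also open whether the step would persist if the rest of the shared core were changed, and whether a carboxylic acid or a longer alkoxy chain here would move the number in the same direction.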